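The source may report more compounds than this note shows. Statements on the series, on what has been measured and on what is new or still open speak of the compounds shown alone.

Working notes on the series. Compound 1 `CNCC1(C)CCN(c2c(F)cc3c(=O)c(C(=O)O)cn(C4CC4)c3c2OC)C1` serves as the reference; in a functional assay on V79 cells (Cricetulus griseus) for cytotoxicity, read by colony formation (a higher number here means a weaker inhibitor, a lower number a stronger inhibitor), compound 1 gives 120 ug/mL. Compound 2 `CNCC1(C)CCN(c2c(F)cc3c(=O)c(C(=O)O)cn(C4CC4)c3c2C(F)(F)F)C1` differs from it by trifluoromethyl in place of methoxy on an aromatic carbon, and in this assay compound 2 gives 230 ug/mL, a step of a 1.9-fold higher number from compound 1 to compound 2 (0.28 log units; within the scatter). Compound 3 `COc1c(N2CCCC(N)C2)c(F)cc2c(=O)c(C(=O)O)cn(C3CC3)c12` carries a different core, the difference being (3-aminopiperidin-1-yl in place of 3-methyl-3-((methylamino)methyl)pyrrolidin-1-yl on an aromatic carbon); in this assay compound 3 gives 69 ug/mL, a step of a 1.7-fold lower number from compound 1 to compound 3 (0.24 log units; within the scatter). Compound 4 `NC1CCCN(c2c(F)cc3c(=O)c(C(=O)O)cn(C4CC4)c3c2C(F)(F)F)C1` has not yet been measured. It differs from compound 3 by trifluoromethyl in place of methoxy on an aromatic carbon, the same kind of change as from compound 1 to compound 2, though here the site is ortho to a 3-aminopiperidin-1-yl group rather than ortho to a 3-methyl-3-((methylamino)methyl)pyrrolidin-1-yl group. In this assay compound 4 is expected to show a 1.9-fold higher number from compound 3 to compound 4 (0.28 log units; within the scatter). For the measured compounds named here, that expectation rests on the single earlier instance, which gave a 1.9-fold higher number from compound 1 to compound 2 (0.28 log units; within the scatter). The estimate for compound 4 is 130 ug/mL, between 60 ug/mL and 280 ug/mL.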

Compound 4, half-maximal inhibitory concentration: > 500 ug/mL
Compound 4: no number, only a limit; the forecaster's own chance of this, stated with the estimate: 5%; at least 3.8-fold (0.58 log units) between middle value and limit.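

In this assay, as far as these compounds go, compound 4 gives > 500 ug/mL, a limit of the assay and not a number, so the true size of its steps stays unknown. Trifluoromethyl in place of methoxy gives an at least 7.2-fold higher number from compound 3 to compound 4 (0.86 log units; beyond the scatter), so the size of this change does not carry over from the core of compound 1 to that of compound 3: the same change on two cores in this assay, a 1.9-fold higher number (0.28 log units; within the scatter) from compound 1 to compound 2 and an at least 7.2-fold higher number (0.86 log units; beyond the scatter) from compound 3 to compound 4, at least 3.7-fold (0.57 log units) apart, beyond the scatter of two such steps One pair of cores shows neither a cause nor a general rule, and the exchange of the amine-bearing ring, which gives an at least 2.1-fold higher number from compound 2 to compound 4 (0.33 log units; beyond the scatter), likewise differs from its earlier counterpart: the same change on two cores in this assay, a 1.7-fold lower number (0.24 log units; within the scatter) from compound 1 to compound 3 and an at least 2.1-fold higher number (0.33 log units; beyond the scatter) from compound 2 to compound 4, at least 3.7-fold (0.57 log units) apart, beyond the scatter of two such steps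

Still open, from the compounds shown here alone, is whether the same dependence appears with a 3-aminopyrrolidin-1-yl group on that aromatic carbon. Going by these compounds, it is also open whether a nitrile or a chlorine in place of methoxy would behave like trifluoromethyl.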